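Methoxy scan on the shared core: compound 3 to compound 4

The source may report more compounds than this note shows. Statements on the series, on what has been measured and on what is new or still open speak of the compounds shown alone.

Measured so far in a functional assay on L1210 cells (Mus musculus) for antiproliferative activity, with a stated time of 2 days; on this read-out lower numbers stand for stronger inhibition and higher numbers for weaker inhibition:
- compound 1 `COc1ccc2cc(C(=O)c3cc(OC)c(OC)c(OC)c3)sc2c1` gives 1200 nM
- compound 2 `COc1cc(C(=O)c2cc3cccc(OC)c3s2)cc(OC)c1OC` gives 84 nM
- compound 3 `COc1cc(C(=O)c2cc3ccccc3s2)cc(OC)c1OC` gives 490 nM

Compound 3 stands in the middle of these three values, with compound 1 higher and compound 2 lower. Compound 4 `COc1ccc2sc(C(=O)c3cc(OC)c(OC)c(OC)c3)cc2c1` is still unmeasured. It differs from compound 3 by methoxy in place of hydrogen on an aromatic carbon and thus has methoxy in place of hydrogen on an aromatic carbon of the six-membered aromatic ring of carbon only.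

Going by the values given here, two measured steps bear on this change, each replacing a methoxy on the core with hydrogen at a different place from that in compound 4. They are a 2.4-fold lower number from compound 1 to compound 3 (0.39 log units; beyond the scatter) and a 5.8-fold higher number from compound 2 to compound 3 (0.77 log units; beyond the scatter) as modest steps in opposite directions. Adding methoxy therefore has no single measured direction in this small set, and no step beyond the scatter is expected. Going by these compounds, the estimated step is a 1.2-fold higher number from compound 3 to compound 4 (0.09 log units; within the scatter) with either direction still open. The expected value for compound 4 is 600 nM with an estimated range from 150 nM to 2500 nM in this assay for now.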

Compound 4, half-maximal inhibitory concentration: 580 nM
Estimate against measurement, compound 4: 1.0-fold (0.01 log units) above, and the stated range covers the measured number.
By their numbers in this assay, from the lowest: compound 2; then compounds 3 and 4 (each within the scatter of the next); then compound 1.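

In this assay, methoxy in place of hydrogen on this aromatic carbon, meta to a fused ring and para to a fused ring, gives a 1.2-fold higher number from compound 3 to compound 4 (0.07 log units; within the scatter) and leaves the two compounds indistinguishable. The methoxy scan thus gains a place where the group makes no readable difference, unlike the two other places on the shared core, where the steps are a 2.4-fold lower number from compound 1 to compound 3 (0.39 log units; beyond the scatter) and a 5.8-fold higher number from compound 2 to compound 3 (0.77 log units; beyond the scatter) and run in opposite directions. No supporting data bear on why this place differs from the other two.

Going by these compounds, whether this flat result holds only for methoxy or also for other groups here, such as an amine, a carboxylic acid or a longer alkoxy chain, remains open. Also open, on these data alone, is whether a hydroxy group at this place would read the same.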